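Lengthening the hydroxamic acid linker on a shared core

This account rests on a few compounds, and the source may have more. Where it says the series, first, only, none or still open, it means among the compounds named here.

Compound 2 `COc1cc2ncnc(Nc3cccc(Br)c3)c2cc1OCCCC(=O)NO` holds the highest of the two numbers in a functional assay on MCF7 cells (Homo sapiens) for antiproliferative activity, read by MTT assay, with a stated time of 48 h (a lower number here means a stronger inhibitor, a higher number a weaker inhibitor), where compound 2 gives 68400 nM. Its nearest neighbour, compound 3 `COc1cc2ncnc(Nc3ccc(Cl)cc3Cl)c2cc1OCCCC(=O)NO`, gives 56800 nM in this assay, and the step of a 1.2-fold lower number from compound 2 to compound 3 (0.08 log units; within the scatter) stays inside the scatter. Compound 1 `COc1cc2ncnc(Nc3cccc(Cl)c3)c2cc1OCCC(=O)NO` reaches only a limit in this assay, > 100000 nM, as recorded by the limit of > 100000 nM in this assay, at which 1 of the 3 values shown sits. Compound 4 `COc1cc2ncnc(Nc3cccc(Br)c3)c2cc1OCCCCCC(=O)NO` differs from compound 2 by 2-(hydroxycarbamoyl)ethyl in place of hydroxycarbamoyl on a saturated chain carbon, three bonds along the chain from an oxygen on an aromatic ring. No measured step touches this chain: the single step shown alters the aryl group and lies within the scatter, and compound 1 differs from compound 2 in two places at once, so its limit cannot be tied to the chain alone. Compound 4 is therefore expected to show a modest step of a 2.3-fold lower number from compound 2 to compound 4 (0.36 log units; beyond the scatter), and its value is estimated at 30000 nM, ranging from 8000 nM to 100000 nM.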

Compound 4, half-maximal inhibitory concentration: 2800 nM
For compound 4 the middle estimate is 11-fold (1.03 log units) above the measured one; the measured number lies below the stated range.
By their numbers in this assay, from the lowest: compound 4; then compounds 3 and 2 (each within the scatter of the next). At a limit, above all of these: compound 1.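

At this chain position, a single change moves the number well beyond the scatter: in this assay, 2-(hydroxycarbamoyl)ethyl in place of hydroxycarbamoyl gives a 24-fold lower number from compound 2 to compound 4 (1.39 log units; beyond the scatter). For the compounds shown here, the only earlier single change, on the aryl group, gave a 1.2-fold lower number from compound 2 to compound 3 (0.08 log units; within the scatter), so the chain now stands out as the more sensitive of the two places, on one step each. Nothing shown accounts for the size of this step.

As far as these compounds go, whether a still longer chain lowers the number further remains open, as does whether a carboxylic acid can replace the hydroxamic acid end. Also open, from the compounds shown here alone, is whether 2,4-dichlorophenyl behaves the same on the chain of compound 4.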